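Changing the Aryl Group on the Urea of Compound 2

The source may hold more compounds than are shown below. What is called first, only, known or untested is meant among the compounds shown, and "the series" means these compounds.

Three compounds share one core and differ only in the aryl group on the urea nitrogen. Compound 1 `Cc1ccc(NC(=O)Nc2cccc(CNc3nccnc3Cl)c2)cc1C` gives 8930 nM in a functional assay on T-24 cells (Homo sapiens) for antiproliferative activity, read by MTT assay, with a stated time of 48 h; on this read-out lower numbers stand for stronger inhibition and higher numbers for weaker inhibition. Compound 2 `Cc1ccc(NC(=O)Nc2cccc(CNc3nccnc3Cl)c2)cc1` gives 9820 nM in this assay, and compound 3 `O=C(Nc1cccc(CNc2nccnc2Cl)c1)Nc1ccccc1F` gives 7450 nM. Compound 2 sits close to both neighbours: the steps of a 1.1-fold higher number from compound 1 to compound 2 (0.04 log units; within the scatter) and a 1.3-fold lower number from compound 2 to compound 3 (0.12 log units; within the scatter) are both within the scatter, as is a 1.2-fold lower number from compound 1 to compound 3 (0.08 log units; within the scatter), so the three numbers cannot be told apart.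

Compound 4 `O=C(Nc1cccc(CNc2nccnc2Cl)c1)Nc1ccc(Cl)cc1Br` is not yet measured. It differs from compound 2 as follows: 2-bromo-4-chlorophenyl in place of 4-methylphenyl on an amide-type nitrogen. Among the compounds with values here, the only measured steps that bear on this are the swaps of the same aryl group, a 1.3-fold lower number from compound 2 to compound 3 (0.12 log units; within the scatter) and a 1.2-fold lower number from compound 1 to compound 3 (0.08 log units; within the scatter), which replaced methyl-bearing phenyl rings with a halogen-bearing one and moved the number only within the scatter. The step to compound 4 is therefore expected to be small in either direction, about a 1.2-fold lower number from compound 2 to compound 4 (0.09 log units; within the scatter). Compound 4 is expected to give 8000 nM in this assay, with a range from 3500 nM to 18000 nM.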

Compound 4, half-maximal inhibitory concentration: 6650 nM
For compound 4 the middle estimate is 1.2-fold (0.08 log units) above the measured one, and the stated range covers the measured number.
By their numbers in this assay, from the lowest: compounds 4, 3, 1 and 2 (each within the scatter of the next).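

Putting a 2-bromo-4-chlorophenyl group on the amide-type nitrogen brings two different halogens onto the ring, yet in this assay the result is a 1.5-fold lower number from compound 2 to compound 4 (0.17 log units; within the scatter) and a 1.1-fold lower number from compound 3 to compound 4 (0.05 log units; within the scatter) and also a 1.3-fold lower number from compound 1 to compound 4 (0.13 log units; within the scatter) with all of these steps inside the usual scatter. The earlier compounds shown here covered only methyl-bearing rings and a single fluorine, so this result extends the flat picture: all four aryl groups, including this one with bromine and chlorine, give numbers that cannot be told apart. No measurement shown here offers an explanation for this flatness.

From the compounds shown here alone, all four groups are phenyl rings carrying only methyl or halogen, so the effect of a ring bearing an amine or a carboxylic acid stays open. Going by these compounds, whether a longer chain in place of the ring would shift the number also remains unknown.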